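Isopropyl for Hydrogen: Compound 3 After Two Limits

The compounds below may be only part of what the source reports. "The series", "measured", "known", "first", "only" and "open" are said of these compounds alone.

Compound 1 `O=c1c2c(C(F)(F)F)cc(-c3ccccc3)nc2ncn1Cc1cn(CCC(F)(F)C(F)(F)C(F)(F)C(F)(F)C(F)(F)C(F)(F)C(F)(F)C(F)(F)F)nn1`: in a functional assay on U-937 cells (Homo sapiens) for cytotoxicity, read by MTT assay, with a stated time of 24 h (a higher number here means a weaker inhibitor, a lower number a stronger inhibitor), compound 1 gives > 200 ug/mL.
Compound 2 `CCc1nc2nc(-c3ccccc3)cc(C(F)(F)F)c2c(=O)n1Cc1cn(CCC(F)(F)C(F)(F)C(F)(F)C(F)(F)C(F)(F)C(F)(F)F)nn1`: in this assay compound 2 gives > 200 ug/mL.

Both values are limits of this assay rather than numbers. For compound 1 this means only that no half-maximal inhibition was reached within the range tested, so compound 1 stands at the top of the scale with no number of its own. Within the data shown here, compound 2 sits at the same limit, and because the limit of > 200 ug/mL in this assay, at which 2 of the 2 values shown sit, nothing separates the two measured compounds; compound 2 also differs from compound 1 in more than one place, so no single step between them is defined.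

Compound 3 `CC(C)c1nc2nc(-c3ccccc3)cc(C(F)(F)F)c2c(=O)n1Cc1cn(CCC(F)(F)C(F)(F)C(F)(F)C(F)(F)C(F)(F)C(F)(F)C(F)(F)C(F)(F)F)nn1` differs from compound 1 by isopropyl in place of hydrogen on an aromatic carbon, in words isopropyl in place of hydrogen on an aromatic carbon. Among the measured compounds shown here, no measured pair differs in this one place, so the size of the step can only be expected. Given that every measured value lies at the limit, compound 3 is expected to remain at it, with an expected step that the limit leaves unreadable from compound 1 to compound 3 not beyond the scatter. Compound 3 is therefore estimated at 250 ug/mL, with a range from 100 ug/mL to 600 ug/mL.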

Compound 3, half-maximal inhibitory concentration: 8.35 ug/mL
For compound 3 the middle estimate is 30-fold (1.48 log units) above the measured one, outside the stated range (below it).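

Placing isopropyl on this aromatic carbon, between two ring nitrogen atoms, gives an at least 23-fold lower number from compound 1 to compound 3 (1.37 log units; beyond the scatter) in this assay, so this one change takes the compound off the limit and gives a real cytotoxicity reading. Compound 1 has no number of its own, so this step is a minimum and the true difference could be larger. Until compound 3, the scale held no number at all, and it still shows that compound 1 and compound 2 rest at a limit of the assay: the limit of > 200 ug/mL in this assay, at which 2 of the 3 values shown sit.

Among these compounds, compound 2 carries ethyl at this position but also has a different chain, so no step involving it can be read, and isopropyl remains the only group at this carbon whose change can be judged. On these data alone, whether a methyl group, an amine or a carboxylic acid on the same carbon would also give a measurable value remains open, as does whether the cytotoxicity of compound 3 extends beyond these U-937 cells.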